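Swapping the pyrazole substituent and its effect on solubility

The compounds below may be only part of what the source reports. "The series", "measured", "known", "first", "only" and "open" are said of these compounds alone.

Compound 1 `C=CC(=O)Nc1cc(-n2c(-c3nc(-c4cnn(C5CCN(C)CC5)c4)cnc3N)nc3ccccc32)ccc1OC` — < 10000 nM
Compound 2 `C=CC(=O)Nc1cccc(-n2c(-c3nc(-c4cnn(CCN5CCN(C)CC5)c4)cnc3N)nc3ccccc32)c1` — 30000 nM

Of the compounds shown here, two share the core and have been tested in a physicochemical assay for solubility, at pH 7.4; on this read-out lower numbers stand for lower solubility and higher numbers for higher solubility. Compound 1 gives < 10000 nM, and this reading is a limit of the assay rather than a number; it is the limit of < 10000 nM in this assay, at which 1 of the 2 values shown sits. For the measured compounds named here, compound 2 gives 30000 nM in this assay, the only number among the values shown. Going by the values given here, no step between measured compounds that differ in one place exists here, so nothing can be said about the effect of any single change on the measured side.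

Compound 3 `C=CC(=O)Nc1cccc(-n2c(-c3nc(-c4cnn(C5CCN(C(C)=O)CC5)c4)cnc3N)nc3ccccc32)c1` has not yet been measured in this assay. It differs from compound 2 by 1-acetylpiperidin-4-yl in place of 2-(4-methylpiperazin-1-yl)ethyl on an aromatic nitrogen. The author expects the step from compound 2 to compound 3 to be a decrease in this assay, of size a 3.0-fold lower number from compound 2 to compound 3 (0.48 log units; beyond the scatter), beyond the usual scatter. The solubility of compound 3 in this assay is estimated at 10000 nM, with a range from 3000 nM to 30000 nM.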

Compound 3, solubility: < 10000 nM
Compound 3 ended at the assay's limit (the forecaster's own chance of this, stated with the estimate: 40%); the middle value sits exactly at the limit.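

Compound 3 gives < 10000 nM in this assay, and this reading is a limit of the assay and not a number. For the compounds shown here, putting 1-acetylpiperidin-4-yl in place of 2-(4-methylpiperazin-1-yl)ethyl on an aromatic nitrogen yields the first step in this set that can be read at a single place, an at least 3.0-fold lower number from compound 2 to compound 3 (0.47 log units; beyond the scatter), so this position does register a change of substituent on this read-out. The step is open on its lower side, and no order can be given among the compounds that sit at that limit: the limit of < 10000 nM in this assay, at which 2 of the 3 values shown sit.

The swap alters several things at once, since the two groups differ in their ring, in the ethyl link and in the acetyl cap, so the compounds shown do not tell which of these parts goes with the step. They also leave open whether a free secondary amine, a carboxylic acid or a longer chain ending in a tertiary amine on the same aromatic nitrogen would read clear of the limit, with the rest of compound 2 kept unchanged.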